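The source may hold more compounds than are shown below. What is called first, only, known or untested is meant among the compounds shown, and "the series" means these compounds.

In an ADME assay on the whole organism (Mus musculus, strain C57BL6/N), read by LC-MS, with a stated time of 24 h, at a dose of 50 mg/kg by the oral route (on this read-out lower numbers stand for lower exposure and higher numbers for higher exposure at the dose given), two compounds have been measured so far:
- compound 1 `CNc1cc(C)c(C(N)=O)cn1` gives 30700 ng.h/mL
- compound 2 `NC(=O)c1cnc2c(c1)CCN2` gives 29000 ng.h/mL

Compound 2 stands level with compound 1: the two numbers lie within the usual scatter of repeated measurements, so they cannot be told apart. The next compound, compound 3 `Cc1c(C(N)=O)cnc2c1CCN2`, keeps the core of compound 2 and makes one change, methyl in place of hydrogen on an aromatic carbon, ortho to a carbamoyl group. For the measured compounds named here, no measured pair shows this change on its own, so there is no direct precedent. The only hint is indirect. Compound 1 carries a methyl group on its aromatic ring and gives 30700 ng.h/mL in the same range as compound 2 , which has none there and gives 29000 ng.h/mL on this measure, though these two also differ elsewhere. No change beyond the scatter is therefore expected. The estimate amounts to a 1.1-fold higher number from compound 2 to compound 3 (0.03 log units; within the scatter) in this assay overall. For compound 3 the expected value is 31000 ng.h/mL with an estimated range of 13000 ng.h/mL to 70000 ng.h/mL for the measurement.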

Compound 3, area under the concentration-time curve: 9220 ng.h/mL
The estimate for compound 3 lay 3.4-fold (0.53 log units) above the measured number; measured number outside the range, below it.
By their numbers in this assay, from the lowest: compound 3; then compounds 2 and 1 (each within the scatter of the next).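

In this assay, putting a methyl group on this aromatic carbon, ortho to a carbamoyl group and opposite the ring nitrogen, gives a 3.1-fold lower number from compound 2 to compound 3 (0.50 log units; beyond the scatter), a step larger than the usual spread of repeat measurements. The earlier compounds shown here offered no pair that isolated a methyl group at this carbon, and this pair shows that a change of only one heavy atom here can clearly lower exposure on the core of compound 2. Nothing available explains why this happens.

The compounds shown leave open whether this drop is specific to methyl or would appear with other groups on the same aromatic carbon, such as a chlorine atom, a methoxy group or a longer chain like ethyl. They also leave open how the curve itself changes, since a single area under the concentration-time curve cannot tell a lower peak concentration from a faster fall in concentration over the stated time.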